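The source may hold more compounds than are shown below. What is called first, only, known or untested is meant among the compounds shown, and "the series" means these compounds.

Compound 1 `Cc1ccc(Nc2cc(NC(=O)Nc3c(Cl)cccc3Cl)ncn2)cc1C` gives 92.1% in a functional assay on PC-9 cells (Homo sapiens) for inhibition, read by MTT assay, with a stated time of 48 h, tested at 10 uM; a lower number here means less inhibition, a higher number more inhibition at the concentration tested (going by the name of the read-out).
Compound 2 `Cc1cc(F)cc(Nc2cc(NC(=O)Nc3c(Cl)cccc3Cl)ncn2)c1` gives 80% in this assay.
Compound 3 `COc1ccc(Nc2cc(NC(=O)Nc3c(Cl)cccc3Cl)ncn2)cc1C` gives 80.1% in this assay.

Among these three, compound 3 stands second highest. Its nearest neighbour is compound 2, with a number 0.1 percentage points higher from compound 2 to compound 3 (within the scatter), and the furthest is compound 1, with a number 12 percentage points lower from compound 1 to compound 3 (beyond the scatter). The unmeasured compound 4 `CCc1ccc(Nc2cc(NC(=O)Nc3c(Cl)cccc3Cl)ncn2)cc1` differs from compound 3 in one place: 4-ethylphenyl in place of 4-methoxy-3-methylphenyl on a nitrogen on an aromatic ring. Within the data shown here, two measured steps bear on this change. Putting methoxy in place of methyl on an aromatic carbon gave a number 12 percentage points lower from compound 1 to compound 3 (beyond the scatter), so taking the methoxy away again in compound 4 might recover part of that drop. The other step, a number 0.1 percentage points higher from compound 2 to compound 3 (within the scatter), shows that exchanging one aryl group for another on the same nitrogen left the number essentially where it was. Among the measured compounds shown here, compound 4 also carries ethyl rather than methyl, which no measured pair covers, so the expectation is held loosely. Compound 4 is expected to show a number 5.9 percentage points higher from compound 3 to compound 4 (within the scatter), a modest rise. The estimate for compound 4 is 86%, within the range 72% to 96%.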

Compound 4, a percentage reported as inhibition, at one concentration (the size of the read-out at that concentration, not a potency): 70.1%
The estimate for compound 4 lay 15.9 percentage points above the measured number, and the stated range ends above it.
By their numbers in this assay, from the lowest: compounds 4, 2 and 3 (each within the scatter of the next); then compound 1.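

Compound 1 now stands apart from all three other compounds in this assay: replacing its 3,4-dimethylphenyl with 4-ethylphenyl on a nitrogen on an aromatic ring gives a number 22 percentage points lower from compound 1 to compound 4 (beyond the scatter), the largest step among these compounds. The other two changes at this position stay within the scatter, with a number 10 percentage points lower from compound 3 to compound 4 (within the scatter) and a number 9.9 percentage points lower from compound 2 to compound 4 (within the scatter), so compound 2, compound 3 and compound 4 cannot be told apart. Compound 4 has no methoxy, yet it does not join compound 1, so the absence of that group alone does not restore the number of compound 1.

Nothing available explains why the 3,4-dimethylphenyl group stands apart. On these data alone, whether an aryl group on this nitrogen carrying an amine, a carboxylic acid or a chain longer than ethyl would match compound 1 remains open.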